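Thioether heteroaryl variation at the ketone-bearing carbon

This account rests on a few compounds, and the source may have more. Where it says the series, first, only, none or still open, it means among the compounds named here.

Compound 1 `CC(C)[C@H](NC(=O)COc1cccc2ccccc12)C(=O)N[C@@H](CC(=O)O)C(=O)COc1cc(C(F)(F)F)n(C)n1` gives 46000 nM in a functional assay on Jurkat cells (Homo sapiens) for inhibition; on this read-out lower numbers stand for stronger inhibition and higher numbers for weaker inhibition.
Compound 2 `CC(C)[C@H](NC(=O)COc1cccc2ccccc12)C(=O)N[C@@H](CC(=O)O)C(=O)CSc1ncc[nH]1` gives > 200000 nM in this assay, a limit rather than a number.
Compound 3 `CC(C)[C@H](NC(=O)COc1cccc2ccccc12)C(=O)N[C@@H](CC(=O)O)C(=O)CSc1nnnn1-c1ccccc1` gives 153000 nM in this assay.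

Compound 3 stands highest of the two numbers; compound 1 lies nearest, with a 3.3-fold higher number from compound 1 to compound 3 (0.52 log units; beyond the scatter). Compound 2 sits at the limit of > 200000 nM in this assay, at which 1 of the 3 values shown sits.

Compound 4 `Cc1cc(C)nc(SCC(=O)[C@H](CC(=O)O)NC(=O)[C@@H](NC(=O)COc2cccc3ccccc23)C(C)C)n1` differs from compound 3 only in the group on sulfur: 4,6-dimethylpyrimidin-2-yl in place of 1-phenyl-1H-tetrazol-5-yl on a sulfur. For the measured compounds named here, two steps bear on this change. The exchange of the group on sulfur between compound 2 and compound 3 gave an at least 1.3-fold lower number from compound 2 to compound 3 (0.11 log units; that floor lies within the scatter), and the exchange of the whole side group gave a 3.3-fold higher number from compound 1 to compound 3 (0.52 log units; beyond the scatter). A further heteroaryl on sulfur is therefore expected to move this assay little, if at all, beyond the scatter.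

Compound 4 is estimated at 130000 nM in this assay, between 40000 nM and 400000 nM, which is expected to mean a 1.2-fold lower number from compound 3 to compound 4 (0.07 log units; within the scatter).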

Compound 4, half-maximal inhibitory concentration: > 200000 nM
Compound 4 ended at the assay's limit (the forecaster's own chance of this, stated with the estimate: 35%); middle value at least 1.5-fold (0.18 log units) from the limit.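

Compound 4 sits at a limit of the assay, not at a number, as compound 2 does, so the step between these two cannot be read: the limit of > 200000 nM in this assay, at which 2 of the 4 values shown sit. The change from 1-phenyl-1H-tetrazol-5-yl to 4,6-dimethylpyrimidin-2-yl on the sulfur gives an at least 1.3-fold higher number from compound 3 to compound 4 (0.11 log units; that floor lies within the scatter), which leaves these two groups unranked. Against the pyrazolyloxy group, this assay shows an at least 4.3-fold higher number from compound 1 to compound 4 (0.63 log units; beyond the scatter), so all three sulfanyl groups now give higher numbers than compound 1.

Going by these compounds, whether the sulfur link or the heteroaryl sets compound 1 apart remains open. A (4,6-dimethylpyrimidin-2-yl)oxy group would separate the two.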